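The compounds below may be only part of what the source reports. "The series", "measured", "known", "first", "only" and "open" are said of these compounds alone.

The measured compounds and their values in a functional assay on SH-SY5Y cells (Homo sapiens) for antiproliferative activity, read by MTT assay, with a stated time of 48 h; a higher number here means a weaker inhibitor of growth, a lower number a stronger inhibitor of growth:
Compound 1 `COc1ccc(N(C)c2ncnc3c2ncn3Cc2ccc(OC)c(OC)c2)cc1` gives 430 nM.
Compound 2 `COc1ccc(N(C)c2nc(Cl)nc3c2ncn3Cc2ccc(OC)c(OC)c2)cc1` gives 7300 nM.
Compound 3 `COc1cc(Cn2cnc3c(Cl)ncnc32)cc(OC)c1` reaches only a limit of the assay, > 100000 nM, not a number.

From compound 1 to compound 2 the change is chloro in place of hydrogen on an aromatic carbon, and it produced a 17-fold higher number from compound 1 to compound 2 (1.23 log units; beyond the scatter) in this assay. Compound 4 `COc1cc(Cn2cnc3c(Cl)nc(Cl)nc32)cc(OC)c1` has not yet been measured. It arises from compound 3 by the same kind of change, (chloro in place of hydrogen on an aromatic carbon); around the place, the new chloro sits meta to a chloro group rather than meta to a (4-methoxyphenyl)(methyl)amino group. How the core of compound 3 differs from the core of compound 1 is not broken down here. Compound 3 already stands at the limit of > 100000 nM in this assay, at which 1 of the 3 values shown sits. Resting on the earlier step, the expected step here is a step that the limit leaves unreadable from compound 3 to compound 4. Compound 4 is expected to give about 200000 nM in this assay, most likely reported again only as a limit.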

Compound 4, concentration for 50% growth inhibition: 1700 nM
The estimate for compound 4 lay 120-fold (2.07 log units) above the measured number; measured number below the stated range.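

In this assay, chloro in place of hydrogen on an aromatic carbon gave an at least 58-fold lower number from compound 3 to compound 4 (1.76 log units; beyond the scatter), the opposite direction to a 17-fold higher number from compound 1 to compound 2 (1.23 log units; beyond the scatter). The effect of this change therefore did not carry over from one core to the other in this pair of steps: the same change on two cores in this assay, a 17-fold higher number (1.23 log units; beyond the scatter) from compound 1 to compound 2 and an at least 58-fold lower number (1.76 log units; beyond the scatter) from compound 3 to compound 4, at least 990-fold (2.99 log units) apart, beyond the scatter of two such steps. What is not shown is which difference between the two cores turns the step around, and the exact size of the new step also stays unknown, as compound 3 stands only at a limit of the assay: the limit of > 100000 nM in this assay, at which 1 of the 4 values shown sits.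

Still open, as far as these compounds go, is how an amine or a carboxylic acid on that same carbon, between two ring nitrogen atoms, would behave on either core.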